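The source may hold more compounds than are shown below. What is called first, only, known or untested is meant among the compounds shown, and "the series" means these compounds.

Compound 1 `COC(=O)C1=C(C)N=C(C)/C(=C(\O)OC)C1c1cccc(OC)c1` gives 191 nM in a functional assay (muscle tissue) with Cavia porcellus as the target (on this read-out lower numbers stand for an effect already at smaller amounts and higher numbers for an effect only at larger amounts of compound), and stands with the highest of the three numbers recorded there. Its nearest neighbour is compound 2 `COC(=O)C1=C(C)N=C(C)/C(=C(\O)OC)C1c1ccc(F)cc1`, which gives 129 nM, so that the step of a 1.5-fold lower number from compound 1 to compound 2 (0.17 log units; within the scatter) is one of 4-fluorophenyl in place of 3-methoxyphenyl on a saturated ring carbon. Farthest from it lies compound 3 `COC(=O)C1=C(C)N=C(C)/C(=C(\O)OC)C1c1ccccc1C`, which gives 6.03 nM; here the step of a 32-fold lower number from compound 1 to compound 3 (1.50 log units; beyond the scatter) comes from 2-methylphenyl in place of 3-methoxyphenyl on a saturated ring carbon, and the step of a 21-fold lower number from compound 2 to compound 3 (1.33 log units; beyond the scatter) points the same way.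

Compound 4 `COC(=O)C1=C(C)N=C(C)/C(=C(\O)OC)C1c1cccc(OC(=O)c2ccccc2)c1` differs from compound 1 by benzoyl in place of methyl on an oxygen on an aromatic ring. Among the compounds with values here, none of the measured steps touches this oxygen: each swaps the whole aryl group. Within the data shown here, the one step that keeps a group on the aryl ring unchanged in kind, from compound 1 to compound 2, stayed within the scatter, while the large steps both involve 2-methylphenyl, which compound 4 does not carry. Compound 4 is therefore expected to give 220 nM, between 70 nM and 700 nM, a step of a 1.2-fold higher number from compound 1 to compound 4 (0.06 log units; within the scatter) that is estimated to stay within the scatter.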

Compound 4, half-maximal effective concentration: 6310 nM
Beside the measured number, compound 4's estimate is 29-fold (1.46 log units) below it, and the stated range ends below it.
By their numbers in this assay, from the lowest: compound 3; then compounds 2 and 1 (each within the scatter of the next); then compound 4.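

In this assay, the oxygen on the aromatic ring proves to be a place where a single change counts: going from methoxy to benzoyloxy gives a 33-fold higher number from compound 1 to compound 4 (1.52 log units; beyond the scatter). The earlier steps from compound 1 swapped the whole aryl group and either stayed within the scatter or led to a lower number, so this is the first step shown that leads to a higher number beyond the scatter. Nothing available here bears on why the number rises with benzoyl on this oxygen.

With only methyl and benzoyl shown on this oxygen, the compounds leave open whether the carbonyl or the added ring goes with the rise. An acetyl group, which carries the carbonyl without the ring, and a benzyl group, which carries the ring without the carbonyl, would separate the two.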